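The source may hold more compounds than are shown below. What is called first, only, known or untested is meant among the compounds shown, and "the series" means these compounds.

Compound 1, `COc1cc(/C=C/C(=O)C2=C(/C=C/c3ccc(O)c(OC)c3)NC(=O)NC2c2ccccc2O)ccc1O`, carries a 2-hydroxyphenyl group on a saturated ring carbon of its core. In a functional assay, with a stated time of 20 min, tested at 50 uM (on this read-out lower numbers stand for a weaker effect and higher numbers for a stronger effect at the one concentration tested), compound 1 gives 88.9%. Compound 2, `COc1cc(/C=C/C(=O)C2=C(/C=C/c3ccc(O)c(OC)c3)NC(=O)NC2c2ccc(N(C)C)cc2)ccc1O`, differs from it in one place: 4-(dimethylamino)phenyl in place of 2-hydroxyphenyl on a saturated ring carbon. In this assay compound 2 gives 56%, which is a number 32.9 percentage points lower from compound 1 to compound 2 (beyond the scatter). Compound 3, `COc1cc(/C=C/C(=O)C2=C(/C=C/c3ccc(O)c(OC)c3)NC(=S)NC2c2ccccc2O)ccc1O`, has a different core; the difference between the two cores is not broken down here. In this assay compound 3 gives 86.3%, a number within the scatter of compound 1. Compound 4, `COc1cc(/C=C/C(=O)C2=C(/C=C/c3ccc(O)c(OC)c3)NC(=S)NC2c2ccc(N(C)C)cc2)ccc1O`, is not yet measured and differs from compound 3 by the same change: 4-(dimethylamino)phenyl in place of 2-hydroxyphenyl on a saturated ring carbon. Because that change cost a number 32.9 percentage points lower from compound 1 to compound 2 (beyond the scatter), a step of similar size is expected, namely a number 32.3 percentage points lower from compound 3 to compound 4 (beyond the scatter). Compound 4 is therefore estimated at 54%, most likely between 36% and 72%.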

Compound 4, a percentage reported as activity, at one concentration (the size of the read-out at that concentration, not a potency): 89.5%
Estimate against measurement, compound 4: 35.5 percentage points below; the measured number lies above the stated range.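

In this assay the same swap on the second core gives a number 3.2 percentage points higher from compound 3 to compound 4 (within the scatter) and so leaves no real change. The change therefore does not carry over from one core to the other as a fixed step: the same change on two cores in this assay, a number 32.9 percentage points lower (beyond the scatter) from compound 1 to compound 2 and a number 3.2 percentage points higher (within the scatter) from compound 3 to compound 4, 36.1 percentage points apart, beyond the scatter of two such steps. This shows that the effect of the swap depends on the core in these two pairs, but it does not show why, and one pair per core says nothing about other groups.

Going by these compounds alone, only two groups appear on this saturated ring carbon. A plain phenyl group on both cores could show whether the large drop on the first core tracks the loss of the hydroxyl or the arrival of the dimethylamino group.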